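Working notes: replacing the 4-hydroxyphenyl of compound 3

The source may report more compounds than this note shows. Statements on the series, on what has been measured and on what is new or still open speak of the compounds shown alone.

Measured in a functional assay on NCI-H23 cells (Homo sapiens) for inhibition, read by sulforhodamine B assay, with a stated time of 48 h; on this read-out lower numbers stand for stronger inhibition of growth and higher numbers for weaker inhibition of growth:
- compound 1 `O=C(Cc1csc2nc(-c3ccc(Br)cc3)cn12)N/N=C/c1ccccc1`: 61700 nM
- compound 2 `O=C(Cc1csc2nc(-c3ccc(Br)cc3)cn12)N/N=C/c1ccccc1O`: 14100 nM
- compound 3 `O=C(Cc1csc2nc(-c3ccc(Br)cc3)cn12)N/N=C/c1ccc(O)cc1`: 32400 nM

In this assay compound 3 gives 32400 nM. That number cannot be separated from the value of compound 1, given a 1.9-fold lower number from compound 1 to compound 3 (0.28 log units; within the scatter), but it stands clear of compound 2, given a 2.3-fold higher number from compound 2 to compound 3 (0.36 log units; beyond the scatter).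

The next change gives compound 4 `COc1cccc(OC)c1/C=N/NC(=O)Cc1csc2nc(-c3ccc(Br)cc3)cn12`, with 2,6-dimethoxyphenyl in place of 4-hydroxyphenyl on a carbon with a double bond to nitrogen.

For the measured compounds named here, no measured compound carries a methoxy group, so no step shows this change directly. The closest evidence is the exchange at the same carbon, a 2.3-fold higher number from compound 2 to compound 3 (0.36 log units; beyond the scatter), which is modest. Adding hydroxy gave a 4.4-fold lower number from compound 1 to compound 2 (0.64 log units; beyond the scatter) in one case and a 1.9-fold lower number from compound 1 to compound 3 (0.28 log units; within the scatter) in the other, so the series has so far moved little in this assay.

On that basis, no change beyond the scatter is expected, and the estimated step is a 1.1-fold lower number from compound 3 to compound 4 (0.03 log units; within the scatter). From the compounds shown here alone, the direction remains open. For compound 4 the expected value is 30000 nM, with an estimated range of 10000 nM to 90000 nM.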

Compound 4, concentration for total growth inhibition: 52500 nM
For compound 4 the middle estimate is 1.8-fold (0.24 log units) below the measured one; measured number inside the range.
By their numbers in this assay, from the lowest: compound 2; then compounds 3, 4 and 1 (each within the scatter of the next).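

In this assay, the 2,6-dimethoxyphenyl group differs from both hydroxy rings in carrying no hydrogen-bond donor, yet compound 4 cannot be separated from the 4-hydroxyphenyl compound (a 1.6-fold higher number from compound 3 to compound 4 (0.21 log units; within the scatter)) or from the unsubstituted phenyl compound (a 1.2-fold lower number from compound 1 to compound 4 (0.07 log units; within the scatter)). The 2-hydroxyphenyl group alone stands clear of the new group (a 3.7-fold higher number from compound 2 to compound 4 (0.57 log units; beyond the scatter)), so compound 2 now has the lowest number, with its steps to all three other compounds beyond the scatter, while compounds 1, 3 and 4 form a group with no separable order. Nothing available explains why the 2-hydroxyphenyl group stands apart at this carbon with a double bond to nitrogen.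

Still open, from the compounds shown here alone, is whether an amine or a carboxylic acid on this aromatic ring would move the number beyond the scatter, and in which direction. The compounds shown also leave open whether the lower number of compound 2 would hold with a chlorine or a methyl group in place of the bromine on the shared core.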